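This account rests on a few compounds, and the source may have more. Where it says the series, first, only, none or still open, it means among the compounds named here.

Compounds measured so far:

compound 1 `COc1ccc2ccc(=O)oc2c1C1=NN(C(C)=O)C(c2ccccc2)C1` — in a functional assay on HepG2 cells (Homo sapiens) for cytotoxicity, read by MTT assay, with a stated time of 72 h (on this read-out lower numbers stand for stronger inhibition and higher numbers for weaker inhibition), compound 1 gives 52 nM
compound 2 `COc1ccc2ccc(=O)oc2c1C1=NN(c2ccccc2)C(c2ccc(C)cc2)C1` — in this assay compound 2 gives 51 nM

Within the data shown here, compound 2 and compound 1 differ in more than one place, so no single step connects them; their two numbers in this assay sit within the usual scatter of each other, and neither can be called the more potent of the pair. Among the measured compounds shown here, compound 2 therefore stands on a par with the only other measured member of the series.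

Compound 3 `COc1ccc2ccc(=O)oc2c1C1=NN(c2ccccc2)C(c2ccccc2)C1` has not yet been measured. It is obtained from compound 2 by one change: hydrogen in place of methyl on an aromatic carbon, in words hydrogen in place of methyl on an aromatic carbon. For the measured compounds named here, no measured pair shows what this change does in this assay, so the size of the step is open. The loss of a single carbon at the edge of the molecule gives no ground to expect a step beyond the scatter in either direction.

For compound 3 the expected value in this assay is 60 nM, with a range from 25 nM to 150 nM. This estimate corresponds to a step of a 1.2-fold higher number from compound 2 to compound 3 (0.07 log units; within the scatter), which is expected to stay within the scatter.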

Compound 3, half-maximal inhibitory concentration: 73 nM
Beside the measured number, compound 3's estimate is 1.2-fold (0.09 log units) below it; the range from low to high includes it.
By their numbers in this assay, from the lowest: compounds 2, 1 and 3 (each within the scatter of the next).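

In this assay, among these compounds, the change from 4-methylphenyl to phenyl gives a 1.4-fold higher number from compound 2 to compound 3 (0.16 log units; within the scatter), the first reading at this place on the ring, para to a large group, and the step stays within the scatter, so the methyl is not required to keep the number in the range of the series. Compound 3 also gives the series its first reading at the ring nitrogen, where phenyl in place of acetyl on an amine nitrogen in a ring gives a 1.4-fold higher number from compound 1 to compound 3 (0.15 log units; within the scatter), again within the scatter, so two very different groups at that nitrogen give numbers that cannot be told apart here. Nothing available explains why either step remains this small.

Open at the para place is whether a group other than methyl or hydrogen, such as chlorine, methoxy, an amine or a carboxylic acid, would give a step beyond the scatter. At the ring nitrogen, the same question holds for a longer acyl chain or a benzyl group, and for hydrogen on that nitrogen.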